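Estimating growth inhibition for a changed phenyl group

This account rests on a few compounds, and the source may have more. Where it says the series, first, only, none or still open, it means among the compounds named here.

- Compound 1 `Cc1cc(=O)c2c(O)cc(OCc3ccc([N+](=O)[O-])cc3)c([C@H]3CCN(C)C[C@H]3O)c2o1` gives 23%
- Compound 2 `Cc1cc(=O)c2c(O)c(CN3CCCC3)c(O)c([C@H]3CCN(C)C[C@H]3O)c2o1` gives 10%
- Compound 3 `Cc1oc2c([C@H]3CCN(C)C[C@H]3O)c(O)cc(O)c2c(=O)c1C(O)c1cccc(Cl)c1` gives 31%

These values come from a functional assay on PC-3 cells (Homo sapiens) for inhibition, read by MTT assay, with a stated time of 48 h, tested at 10 uM; a higher number here means more inhibition of growth at the concentration tested, a lower number less inhibition of growth. Compound 3 lies within the scatter of compound 1 and beyond the scatter above compound 2. Compound 4 `COc1ccc(C(O)c2c(C)oc3c([C@H]4CCN(C)C[C@H]4O)c(O)cc(O)c3c2=O)cc1Br` has not been measured yet. It carries 3-bromo-4-methoxyphenyl in place of 3-chlorophenyl on a saturated chain carbon bound to an aromatic carbon and an oxygen on a saturated carbon. Among the compounds with values here, no measured step shows what such a swap does, so the expectation starts from compound 3 (31%) and foresees no change beyond the scatter in this assay. The expected change is a number 3 percentage points lower from compound 3 to compound 4 (within the scatter) and stays within the scatter. Compound 4 is estimated to read 28% (range 12% to 45%).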

Compound 4, percent growth inhibition at one concentration: 0%
Compound 4: the middle estimate sits 28 percentage points above what was measured; measured number outside the range, below it.
By their numbers in this assay, from the lowest: compounds 4 and 2 (each within the scatter of the next); then compounds 1 and 3 (each within the scatter of the next).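

Swapping 3-chlorophenyl for 3-bromo-4-methoxyphenyl in this assay gives a number 31 percentage points lower from compound 3 to compound 4 (beyond the scatter) and is the only single-place change shown. So the group on this (hydroxy)methyl carbon is not a free choice: with the core unchanged, one change of the phenyl substituents is enough to move the reading beyond the scatter. Nothing available explains this drop.

Which part of the new group goes with the loss stays open, the bromine or the methoxy. Plain 3-bromophenyl and 4-methoxyphenyl at this place would separate the two, and a phenyl bearing an amine would show how far the position tolerates other groups.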